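A difluorophenyl amide follows an ethoxyphenyl amide

The compounds below may be only part of what the source reports. "The series", "measured", "known", "first", "only" and "open" are said of these compounds alone.

Compound 1, `CCCNC(=O)Nc1cc2nc(C3CCCCC3)[nH]c2cc1N1CCCC1`: in an ADME assay on Vero cells (Chlorocebus sabaeus) for cytotoxicity, read by resazurin assay, with a stated time of 3 days (a lower number here means a stronger inhibitor, a higher number a weaker inhibitor), compound 1 gives > 100 ug/mL, a limit of the assay.
Compound 2, `CCOc1ccc(C(=O)Nc2cc3nc(C4CCCCC4)[nH]c3cc2N(CC)CC)cc1`: compound 2 gives > 100 ug/mL, likewise a limit.
Compound 3, `O=C(Nc1cc2nc(C3CCCCC3)[nH]c2cc1N1CCCC1)c1ccccc1`: compound 3 gives > 100 ug/mL, also a limit.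

Compound 2 therefore stands at the ceiling of this assay, as all three measured compounds do (the limit of > 100 ug/mL in this assay, at which 3 of the 3 values shown sit). For the measured compounds named here, the only step between measured compounds, a step that the two limits leave unreadable from compound 1 to compound 3, is left unreadable by the two limits at its ends, so no measured step gives a size to lean on. Compound 4, `CCN(CC)c1cc2[nH]c(C3CCCCC3)nc2cc1NC(=O)c1ccc(F)cc1F`, differs from compound 2 by 2,4-difluorophenyl in place of 4-ethoxyphenyl on a carbonyl carbon. With nothing measured pointing either way, compound 4 is expected to show no step beyond the scatter, a number no higher from compound 2 to compound 4 (the limit leaves the size open). Compound 4 is estimated at 100 ug/mL in this assay, within 50 ug/mL to 200 ug/mL, most likely reported again only as a limit.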

Compound 4, half-maximal inhibitory concentration: > 100 ug/mL
Compound 4: a limit, no number; the forecaster's own chance of this, stated with the estimate: 80%; the middle value sits exactly at the limit.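

The step from compound 2 to compound 4 cannot be read, because both values are limits: the limit of > 100 ug/mL in this assay, at which 4 of the 4 values shown sit.

The compounds shown leave open where any true value lies in this assay, and whether exchanging these groups changes it.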